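The compounds below may be only part of what the source reports. "The series", "measured", "known", "first", "only" and "open" are said of these compounds alone.

Working notes on the series. Compound 1 `CCn1c(C(=O)NCCN(C)C)ccc1C(CC)(CC)c1ccc(OCCC(O)(CC)CC)c(C)c1` and compound 2 `CCn1c(C(=O)N(C)CC(=O)O)ccc1C(CC)(CC)c1ccc(OCCC(O)(CC)CC)c(C)c1` share one core and differ only in the group on the carbonyl carbon. In an assay on cells for agonist activity at vitamin D3 receptor (Homo sapiens), with a stated time of 96 h (a higher number here means that more compound is needed for the effect, a lower number that less compound is needed), compound 1 gives 82 nM, and compound 2 gives 89 nM. The step of a 1.1-fold higher number from compound 1 to compound 2 (0.04 log units; within the scatter) stays within the scatter, so the two amide variants are not separated by this measurement. Among the compounds with values here, of the two numbers, compound 2 holds the nominally higher one, its only neighbour being compound 1 at a gap within the scatter.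

Compound 3 `CCn1c(C(=O)NC(C)C(=O)O)ccc1C(CC)(CC)c1ccc(OCCC(O)(CC)CC)c(C)c1` is the next member: (1-carboxyethyl)amino in place of (carboxymethyl)(methyl)amino on a carbonyl carbon. Within the data shown here, the single measured step that bears on it, a 1.1-fold higher number from compound 1 to compound 2 (0.04 log units; within the scatter), is within the scatter. Therefore for compound 3 in this assay a step of a 1.0-fold higher number from compound 2 to compound 3 (0.00 log units; within the scatter) is expected, that is none beyond the scatter. Compound 3 is estimated at 90 nM, with a range from 40 nM to 200 nM.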

Compound 3, half-maximal effective concentration: 66 nM
Compound 3: middle estimate off by 1.4-fold (0.13 log units), on the high side, within the range that was stated.
By their numbers in this assay, from the lowest: compounds 3, 1 and 2 (each within the scatter of the next).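

In this assay, the change to (1-carboxyethyl)amino on a carbonyl carbon gives a 1.3-fold lower number from compound 2 to compound 3 (0.13 log units; within the scatter), so a rearrangement of the same heavy atoms, with the methyl moved from the nitrogen to the chain and the amide hydrogen present in compound 3, does not separate these two compounds. The pair sharing the amide hydrogen gives a 1.2-fold lower number from compound 1 to compound 3 (0.09 log units; within the scatter), which places 1-carboxyethyl and 2-(dimethylamino)ethyl on an amide-type nitrogen within the scatter, a cleaner comparison of a carboxylic acid with an amine than the earlier step. Nothing available gives a reason for this lack of separation.

Going by these compounds, it remains open whether a plain methyl amide, carrying neither an amine nor a carboxylic acid, would fall in the same range. The same question stands for a longer chain ending in a carboxylic acid and for piperidine on the carbonyl carbon.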